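This account rests on a few compounds, and the source may have more. Where it says the series, first, only, none or still open, it means among the compounds named here.

Of the compounds shown here, three built on one shared core have been tested in a functional assay on SW480 cells (Homo sapiens) for cytotoxicity, read by MTT assay, with a stated time of 24 h; a lower number here means a stronger inhibitor, a higher number a weaker inhibitor. Among the compounds with values here, compound 1 `C=CC1=C(C(=O)NCc2ccc(C)cc2)C(c2ccc(F)cc2)OC1` is the first of them. In this assay compound 1 gives > 100000 nM, which is a limit of the assay rather than a measured number. Compound 2 `C=CC1=C(C(=O)O)C(c2ccc(OC)cc2)OC1` is the second. In this assay compound 2 gives > 100000 nM, again only a limit. Compound 3 `C=CC1=C(C(=O)NCC(C)C)C(c2ccc(F)cc2)OC1` is the third. In this assay compound 3 gives > 100000 nM, also a limit, so compound 3 stands at the same edge of the assay as the other two. Within the data shown here, the only single-point step among them, a step that the two limits leave unreadable from compound 1 to compound 3, cannot be sized, because the limit of > 100000 nM in this assay, at which 3 of the 3 values shown sit, leaves no number on either side of it.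

Compound 4 `C=CC1=C(C(=O)NC2CCCCC2)C(c2ccc(F)cc2)OC1` differs from compound 3 in one place: cyclohexyl in place of isobutyl on an amide-type nitrogen. Among the measured compounds shown here, no measured step gives a readable size for a change of this kind, so nothing points to a shift beyond the scatter. Compound 4 is therefore expected to sit near the same edge, with an estimated step that the limit leaves unreadable from compound 3 to compound 4 and an estimated value of 150000 nM, within a range from 50000 nM to 500000 nM.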

Compound 4, half-maximal inhibitory concentration: > 100000 nM
Compound 4: only a limit was reported; the forecaster's own chance of this, stated with the estimate: 85%; the middle value lies beyond the limit too.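

No step from compound 1 or compound 3 to compound 4 can be read in this assay, because all of them stop at one edge: the limit of > 100000 nM in this assay, at which 4 of the 4 values shown sit.

The compounds shown leave open whether any group on the amide-type nitrogen of the shared core gives a readable value in this assay.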